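Series notes: compound 4 without the chloro group

The source may hold more compounds than are shown below. What is called first, only, known or untested is meant among the compounds shown, and "the series" means these compounds.

Measured so far:
compound 1, `C/C(=N\NC(=S)Nc1cccc(I)c1)c1ccccn1`, gives 84 nM in a functional assay on U-87MG ATCC cells (Homo sapiens) for cytotoxicity, read by MTT assay, with a stated time of 48 h; a lower number here means a stronger inhibitor, a higher number a weaker inhibitor
compound 2, `C/C(=N/NC(=S)Nc1ccccc1Cl)c1ccccn1`, gives 2.6 nM
compound 3, `C/C(=N\NC(=S)Nc1ccccc1Cl)c1ccccn1`, gives 2.6 nM

Compound 3 stands level with compound 2, the two together the lowest of the three numbers, while compound 1 sits far higher. The step of no change at the digits printed from compound 2 to compound 3 (within the scatter) is consistent with the fact that compounds 2 and 3 differ only in the configuration as drawn.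

Compound 4, `C/C(=N\NC(=S)Nc1ccccc1)c1ccccn1`, differs from compound 3 by hydrogen in place of chloro on an aromatic carbon. Among the measured compounds shown here, no measured step covers this change; compound 1 and compound 3 differ in more than one place, and their values show only that compound 1 has the higher number. Compound 4 is therefore expected to give a moderately higher number, a 5.8-fold higher number from compound 3 to compound 4 (0.76 log units; beyond the scatter), with wide uncertainty. Compound 4 is estimated at 15 nM in this assay, between 3 nM and 80 nM.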

Compound 4, half-maximal inhibitory concentration: 1.4 nM
Compound 4: the middle estimate sits 11-fold (1.03 log units) above what was measured; measured number below the stated range.
By their numbers in this assay, from the lowest: compounds 4, 2 and 3 (each within the scatter of the next); then compound 1.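

In this assay, chloro is not needed on this aromatic carbon ortho to a large group, as hydrogen in its place gives a 1.9-fold lower number from compound 3 to compound 4 (0.27 log units; within the scatter). Hydrogen in place of iodo on an aromatic carbon matters far more, giving a 60-fold lower number from compound 1 to compound 4 (1.78 log units; beyond the scatter). Nothing available bears on the reason for either step.

Open, as far as these compounds go, is whether an amine, a carboxylic acid or a methoxy group on the same aromatic carbon would keep the number level with compound 4. Also open, from the compounds shown here alone, is whether chloro and iodo would differ if they sat on the same aromatic carbon.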